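The compounds below may be only part of what the source reports. "The series", "measured", "known", "first", "only" and "open" are said of these compounds alone.

Compound 1 `CC(C)(C)OC(=O)Nc1ncc(C(Oc2cccc(C#N)c2)c2ccc(Cl)cc2)s1` and compound 2 `CCOC(=O)CCCNc1ncc(C(Oc2ccc3cc(Br)ccc3c2)c2ccc(Cl)cc2)s1` share a core and differ in the group carried on the ring nitrogen and in the aryl ether. In an ADME assay on HepG2 2.2.15 cells (Homo sapiens) for cytotoxicity (a higher number here means that more compound is tolerated, a lower number that less compound is tolerated), compound 1 reaches only a limit of the assay, > 50000 nM. Compound 2 is recorded in this assay as "not toxic" (no number reported), with no number attached. For the measured compounds named here, compound 2 therefore stands without a single value; the one other value shown is the limit of > 50000 nM in this assay, at which 1 of the 2 values shown sits. Compound 3 `O=S(=O)(Nc1ncc(C(Oc2ccc3cc(Br)ccc3c2)c2ccc(Cl)cc2)s1)c1cccs1` differs from compound 2 by a single change: (thiophen-2-yl)sulfonyl in place of 3-(ethoxycarbonyl)propyl on a nitrogen on an aromatic ring. Going by the values given here, no measured pair isolates this change, so its size in this assay has not been observed. The writer expects no step beyond the usual scatter in either direction, with the result for compound 3 likely to sit at or near the limit of the assay again. Compound 3 is estimated at 50000 nM in this assay, within a range of 20000 nM to 100000 nM.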

Compound 3, half-maximal cytotoxic concentration: "not toxic" (no number reported)
The entry for compound 3 holds no number; no gap can be computed for the estimate.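

Compound 2 and compound 3 are both recorded as "not toxic" in this assay, with no number attached, so no step can be read between them. Going by these compounds, whether (thiophen-2-yl)sulfonyl in place of 3-(ethoxycarbonyl)propyl shifts the tolerated concentration at all remains open.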